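The source may hold more compounds than are shown below. What is called first, only, known or untested is meant among the compounds shown, and "the series" means these compounds.

Measured compounds:
compound 1 `CCCN1CCN(c2ccccc2[N+](=O)[O-])CC1` — 7.94
compound 2 `CCCN1CCN(c2ccc([N+](=O)[O-])cc2)CC1` — 7.59
compound 3 `CCCN1CCN(c2ccccc2C#N)CC1` — 7.92

All three share the same core, a propyl-bearing piperazine joined to a ring that carries either a nitro or a cyano group. In a physicochemical assay for acid dissociation, using potentiometric titration, compound 1 gives 7.94. Compound 3 differs from compound 1 by cyano in place of nitro on an aromatic carbon, and that exchange made a step of a number 0.02 log units lower from compound 1 to compound 3 (within the scatter), so the two numbers cannot be told apart. Compound 2 is built from the same atoms as compound 1, joined differently; the difference between the two cores is not broken down here. Compound 2 gives 7.59. Compound 3 gives 7.92. The gap between compound 2 and compound 3, and the gap between compound 2 and compound 1, both lie beyond the scatter.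

Compound 4 `CCCN1CCN(c2ccc(C#N)cc2)CC1` has not yet been measured in this assay. It differs from compound 2 by cyano in place of nitro on an aromatic carbon. Among the measured compounds shown here, this is the same kind of change as the one from compound 1 to compound 3, but the place is not the same: there the group was ortho to a group of 9 heavy atoms, here it is para to it. Because the earlier step was a number 0.02 log units lower from compound 1 to compound 3 (within the scatter), only a small step is expected from compound 2 to compound 4, a number 0.06 log units higher from compound 2 to compound 4 (within the scatter). Compound 4 is therefore expected to give about 7.65, with a range from 7.4 to 7.9.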

Compound 4, acid dissociation constant: 7.78
The estimate for compound 4 lay 0.13 log units below the measured number, and the stated range covers the measured number.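

In this assay the exchange of nitro for cyano on an aromatic carbon gives a step (a number 0.19 log units higher from compound 2 to compound 4 (within the scatter)), and on the core of compound 1 the same exchange gives another (a number 0.02 log units lower from compound 1 to compound 3 (within the scatter)). So the exchange carries over from one core to the other in a limited sense: in both pairs the step cannot be told apart from the ordinary spread of repeat measurements, even though the group sits at a different place in the two pairs, para to a group of 9 heavy atoms in compound 4. Two pairs do not show that the exchange would stay this small on any other core, nor that it has no effect at all, and nothing available here speaks to why the steps came out as they did.

The compounds shown leave open whether an amine or a carboxylic acid in place of nitro on the same aromatic carbon would also give a step within the scatter. They also leave open whether the nitro and cyano pairs would behave alike if a longer chain, such as butyl, stood in place of propyl on the shared core.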